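The compounds below may be only part of what the source reports. "The series", "measured", "known", "first", "only" and "open" are said of these compounds alone.

Compound 3 `CC/C(=C(/c1ccc(/C=C/C(=O)O)cc1)c1cc2ccccc2[nH]1)c1cccc(Cl)c1Cl` shares its core with compound 1 `CC/C(=C(/c1ccc(/C=C/C(=O)O)cc1)c1cc2ccccc2[nH]1)c1ccccc1OC(F)(F)F` and compound 2 `CC/C(=C(/c1ccc(/C=C/C(=O)O)cc1)c1cc2ccccc2[nH]1)c1cccc(OC(F)(F)F)c1`; the three differ only in the aryl group on a double-bonded chain carbon bound to a double-bonded chain carbon and a saturated chain carbon. In a functional assay on MCF7 cells (Homo sapiens) for inhibition (a higher number here means a weaker inhibitor, a lower number a stronger inhibitor), compound 1 gives 206 nM, compound 2 gives 282 nM and compound 3 gives 898 nM. Compound 3 thus carries the highest number of the three: the nearest is compound 2, with a 3.2-fold higher number from compound 2 to compound 3 (0.50 log units; beyond the scatter), the furthest compound 1, with a 4.4-fold higher number from compound 1 to compound 3 (0.64 log units; beyond the scatter), whereas the shift between the two trifluoromethoxy isomers, a 1.4-fold higher number from compound 1 to compound 2 (0.14 log units; within the scatter), stays within the scatter. Compound 4 `CC/C(=C(/c1ccc(/C=C/C(=O)O)cc1)c1cc2ccccc2[nH]1)c1ccc(Cl)c(C(F)(F)F)c1` has not yet been measured.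

4-chloro-3-(trifluoromethyl)phenyl in place of 2,3-dichlorophenyl on a double-bonded chain carbon bound to a double-bonded chain carbon and a saturated chain carbon

The two measured steps that bear on this change, a 4.4-fold higher number from compound 1 to compound 3 (0.64 log units; beyond the scatter) and a 3.2-fold higher number from compound 2 to compound 3 (0.50 log units; beyond the scatter), both run from a trifluoromethoxyphenyl to the 2,3-dichlorophenyl and both raise the number modestly. For the measured compounds named here, the incoming 4-chloro-3-(trifluoromethyl)phenyl keeps one chlorine and brings a trifluoromethyl, so it matches none of the measured aryl groups, and no step from 2,3-dichlorophenyl to it exists in the data. Against that background a modest lowering of the number is expected, as a 1.8-fold lower number from compound 3 to compound 4 (0.25 log units; within the scatter). Compound 4 is therefore estimated at 500 nM, with a range from 150 nM to 1600 nM.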

Compound 4, half-maximal inhibitory concentration: 2200 nM
The estimate for compound 4 lay 4.4-fold (0.64 log units) below the measured number; the measured number lies above the stated range.
By their numbers in this assay, from the lowest: compounds 1 and 2 (each within the scatter of the next); then compound 3; then compound 4.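

In this assay the 4-chloro-3-(trifluoromethyl)phenyl group carries the highest number of the four aryl groups, with a 2.4-fold higher number from compound 3 to compound 4 (0.39 log units; beyond the scatter) and a 7.8-fold higher number from compound 2 to compound 4 (0.89 log units; beyond the scatter) and an 11-fold higher number from compound 1 to compound 4 (1.03 log units; beyond the scatter) and all three steps lie beyond the scatter. The earlier compounds shown here showed only that the 2,3-dichlorophenyl stood apart from the two trifluoromethoxy isomers, whereas this result shows a wider span at this position on the double-bonded chain carbon, and among the four compounds both chlorine-bearing aryl groups carry higher numbers than both trifluoromethoxyphenyl groups, with no compound going against that. No measurement at hand explains the rise, so it stands as an observation about this change alone.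

The compounds shown leave open whether the higher number of compound 4 follows its chlorine or its trifluoromethyl, since the two enter together and no aryl group here carries either one on its own. They also leave open how an aryl group bearing a nitrile, an amine or a methoxy would read at this position, and whether a plain phenyl would sit closer to compound 1 or to compound 4.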